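Compound 3 to compound 4: a 3-bromophenyl exchange

The source may hold more compounds than are shown below. What is called first, only, known or untested is meant among the compounds shown, and "the series" means these compounds.

Measured in a functional assay; on this read-out lower numbers stand for stronger inhibition and higher numbers for weaker inhibition:
- compound 1 `CC(C)=CCOc1ccc2c(c1)OC(c1cccc(Br)c1)CC2=O`: 5280 nM
- compound 2 `CC(C)=CCOc1cc(O)c2c(c1)OC(c1ccccc1F)CC2=O`: 5300 nM
- compound 3 `CC(C)=CCOc1cc(O)c2c(c1)OC(c1ccc(Cl)cc1Cl)CC2=O`: 3340 nM

Compound 3, at 3340 nM, lies within the scatter of both compound 1 and compound 2, so the three values do not separate. Compound 4 `CC(C)=CCOc1cc(O)c2c(c1)OC(c1cccc(Br)c1)CC2=O` carries 3-bromophenyl in place of 2,4-dichlorophenyl on a saturated ring carbon. Among the compounds with values here, the one measured step at that carbon, a 1.6-fold lower number from compound 2 to compound 3 (0.20 log units; within the scatter), stayed within the scatter. Compound 1 bears the same 3-bromophenyl on a different core and gives 5280 nM. In this assay, no step beyond the scatter is therefore expected. The expected step is a 1.2-fold higher number from compound 3 to compound 4 (0.08 log units; within the scatter). For compound 4 the estimated value is 4000 nM, with an expected range from 1800 nM to 9000 nM.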

Compound 4, half-maximal inhibitory concentration: 4040 nM
The estimate for compound 4 lay 1.0-fold (0.00 log units) below the measured number; measured number inside the range.
By their numbers in this assay, from the lowest: compounds 3, 4, 1 and 2 (each within the scatter of the next).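

In this assay the step of a 1.2-fold higher number from compound 3 to compound 4 (0.08 log units; within the scatter) and the step of a 1.3-fold lower number from compound 2 to compound 4 (0.12 log units; within the scatter) both stay within the scatter, so 3-bromophenyl, 2,4-dichlorophenyl and 2-fluorophenyl do not separate on this saturated ring carbon next to the ring oxygen. Within the data shown here, the step of a 1.3-fold lower number from compound 1 to compound 4 (0.12 log units; within the scatter) gives the first reading of hydroxy in place of hydrogen on an aromatic carbon, and this exchange also stays within the scatter. Nothing available explains why these values lie so close together.

Going by these compounds, it remains open whether an amine or a carboxylic acid on the phenyl ring would give a step beyond the scatter. The same question stands for a cyclohexyl group in place of the phenyl ring.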